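Compound 1 and its bromo counterpart, compound 3

A few compounds are considered here, and "the series" means these few. Any claim that something is new, unique, unknown or untested is made for them only; others in the source may bear on it.

In a functional assay on MCF7 cells (Homo sapiens) for cytotoxicity, read by MTT assay, with a stated time of 48 h (on this read-out lower numbers stand for stronger inhibition and higher numbers for weaker inhibition), compound 1 (`CCN(CC)C(=S)SC(CC(=O)c1ccccc1)c1ccccc1`) gives 17000 nM. Within the data shown here, its only measured neighbour, compound 2 (`CCN(CC)C(=S)SC(CC(=O)c1ccccc1)c1ccc(C)cc1`), gives 20000 nM, and the two values lie within the scatter of each other. Compound 3 (`CCN(CC)C(=S)SC(CC(=O)c1ccccc1)c1ccc(Br)cc1`) carries bromo in place of hydrogen on an aromatic carbon. Among the measured compounds shown here, the one measured step bearing on this is methyl in place of hydrogen on an aromatic carbon, a 1.2-fold higher number from compound 1 to compound 2 (0.07 log units; within the scatter). For the measured compounds named here, no measured compound carries bromo, so this guide is thin. The estimate is a 1.1-fold lower number from compound 1 to compound 3 (0.05 log units; within the scatter), and no change beyond the scatter is expected. Compound 3 is expected to give about 15000 nM, with an estimated range of 7000 nM to 30000 nM.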

Compound 3, half-maximal inhibitory concentration: 80 nM
The estimate for compound 3 lay 190-fold (2.27 log units) above the measured number; the measured number lies below the stated range.
By their numbers in this assay, from the lowest: compound 3; then compounds 1 and 2 (each within the scatter of the next).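

The place on the aromatic ring that seemed indifferent when methyl replaced hydrogen proves highly sensitive to the group it carries. Bromo gives a 210-fold lower number from compound 1 to compound 3 (2.33 log units; beyond the scatter) and, set against methyl at the same place, gives a 250-fold lower number from compound 2 to compound 3 (2.40 log units; beyond the scatter) so the effect belongs to bromo rather than to any replacement of hydrogen there. No available evidence explains this large drop. The compounds shown leave open whether chloro or iodo at this place would match bromo. They also leave open whether methoxy would produce any comparable change.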